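Sulfonyl substituent change on an 8-phenylxanthine core

A few compounds are considered here, and "the series" means these few. Any claim that something is new, unique, unknown or untested is made for them only; others in the source may bear on it.

Measured compounds:
compound 1, `CCn1c(=O)c2nc(-c3ccc(S(=O)(=O)NCCCN(C)C)cc3)[nH]c2n(CC)c1=O`, 1.6 nM
compound 2, `Cc1ccc(-c2nc3c(=O)n(C)c(=O)n(C)c3[nH]2)cc1`, 0.8 nM

Two compounds are in hand. In an assay for binding affinity to adenosine receptor A1 (Bos taurus) (on this read-out higher numbers stand for weaker inhibition and lower numbers for stronger inhibition), compound 1 gives 1.6 nM, the higher of the two numbers; in this assay compound 2 gives 0.8 nM, and the gap between compound 1 and compound 2 lies within the usual scatter, so the two are read as equivalent on this read-out. Among the compounds with values here, both carry the same core with an aryl group attached to it and differ in the substituents on the core nitrogens and on the aryl ring, but no single-change pair exists among them.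

The next compound is compound 3, `CCn1c(=O)c2nc(-c3ccc(S(=O)(=O)O)cc3)[nH]c2n(CC)c1=O`. Relative to compound 1 the change is hydroxy in place of (3-(dimethylamino)propyl)amino on a sulfonyl sulfur. The aryl ring, the sulfonyl group and the rest of the core are kept; only what sits on the sulfonyl sulfur is exchanged, from the seven-heavy-atom amine-bearing chain to a single oxygen.

Within the data shown here, no measured pair shows this kind of exchange, so its size in this assay cannot be read from the series. The expectation is that compound 3 will give a clearly higher number than compound 1, a step of a 31-fold higher number from compound 1 to compound 3 (1.49 log units; beyond the scatter), well beyond the scatter. For compound 3 the estimate in this assay is 50 nM, with a range from 10 nM to 300 nM.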

Compound 3, half-maximal inhibitory concentration: 755 nM
Compound 3: middle estimate off by 15-fold (1.18 log units), on the low side; measured number above the stated range.
By their numbers in this assay, from the lowest: compounds 2 and 1 (each within the scatter of the next); then compound 3.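

In this assay, what sits on the sulfonyl sulfur has a large effect: hydroxy in place of (3-(dimethylamino)propyl)amino gives a 470-fold higher number from compound 1 to compound 3 (2.67 log units; beyond the scatter), with the aryl ring, the sulfonyl group and the rest of the core kept. Within the data shown here, compound 1 and compound 2 differ in more than one place and offered no single-change reading, so this is the first measured size of any change, and it shows that the shared core and aryl ring alone do not keep the numbers as low as those of compound 1 and compound 2. No supporting data bear on what lies behind the size of this step.

The exchange swaps a whole amine-bearing chain for a single oxygen, so the contributions of losing the chain and of gaining the hydroxy cannot be separated from this pair. Still open, as far as these compounds go, is where an unsubstituted sulfonamide, a sulfonamide with a shorter chain such as 2-(dimethylamino)ethylamino, or a carboxylic acid in place of the sulfo group would fall relative to compound 1 and compound 3.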